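This account rests on a few compounds, and the source may have more. Where it says the series, first, only, none or still open, it means among the compounds named here.

Compound 1 `COc1cc(NC(C)CCCNC(=O)Nc2cccc(O)c2)c2ncccc2c1` gives 48000 nM 
Compound 2 `COc1cc(NC(C)CCCNC(=O)Nc2ccc(C(F)(F)F)cc2)c2ncccc2c1` gives 8300 nM 
Compound 3 `COc1cc(NC(C)CCCNC(=O)Nc2cccc(C(F)(F)F)c2)c2ncccc2c1` gives 14000 nM 

All three values come from a functional assay on HeLa cells (Homo sapiens) for inhibition, read by MTT assay, with a stated time of 72 h (on this read-out lower numbers stand for stronger inhibition and higher numbers for weaker inhibition), and the three compounds share one core. Compound 1 has the highest number, while compound 3 sits with compound 2 at the low end. The measurements show a 1.7-fold higher number from compound 2 to compound 3 (0.23 log units; within the scatter) so these two cannot be ranked against each other.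

The unmeasured compound 4 `COc1cc(NC(C)CCCNC(=O)Nc2ccc(O)cc2)c2ncccc2c1` carries 4-hydroxyphenyl in place of 3-(trifluoromethyl)phenyl on an amide-type nitrogen. Among the compounds with values here, compound 4 therefore has a hydroxy group like compound 1, and no measured step compares the two hydroxyphenyl groups directly.

Two steps offer the best guide. The measurements show a 3.4-fold lower number from compound 1 to compound 3 (0.54 log units; beyond the scatter) and also a 5.8-fold lower number from compound 1 to compound 2 (0.76 log units; beyond the scatter) and both go from a hydroxy group to a trifluoromethyl group. Read backwards, they suggest that the number should rise on going to a hydroxy group. The change of trifluoromethyl position stayed within the scatter, which gives no reason to expect compound 4 to stand far from compound 1.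

An estimated rise of this modest size is expected in this assay as a 2.9-fold higher number from compound 3 to compound 4 (0.46 log units; beyond the scatter) beyond the scatter if the estimate holds. Compound 4 is expected at 40000 nM with an estimated range from 15000 nM to 100000 nM as its likely span.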

Compound 4, half-maximal inhibitory concentration: 70000 nM
Estimate against measurement, compound 4: 1.8-fold (0.24 log units) below, within the range that was stated.
By their numbers in this assay, from the lowest: compounds 2 and 3 (each within the scatter of the next); then compounds 1 and 4 (each within the scatter of the next).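

In this assay, within the data shown here, the new result gives the first direct comparison of the two hydroxyphenyl groups on the amide-type nitrogen: there is a 1.5-fold higher number from compound 1 to compound 4 (0.16 log units; within the scatter), so 4-hydroxyphenyl and 3-hydroxyphenyl cannot be told apart here, just as the two trifluoromethylphenyl groups could not be, with a 1.7-fold higher number from compound 2 to compound 3 (0.23 log units; within the scatter). Among these compounds, both hydroxy compounds now have clearly higher numbers than both trifluoromethyl compounds, with no exception among the four: alongside the earlier steps from compound 1, there is a 5.0-fold higher number from compound 3 to compound 4 (0.70 log units; beyond the scatter) and an 8.4-fold higher number from compound 2 to compound 4 (0.93 log units; beyond the scatter). The exchange of hydroxy and trifluoromethyl on an aromatic carbon can now also be read twice with the group's position held constant, and the two readings agree in direction and, within the scatter, in size: the same change on two cores in this assay, a 3.4-fold lower number (0.54 log units; beyond the scatter) from compound 1 to compound 3 and an 8.4-fold lower number (0.93 log units; beyond the scatter) from compound 4 to compound 2, 2.5-fold (0.39 log units) apart, within the scatter of two such steps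

A plain phenyl group would show whether the gap follows the presence of hydroxy, the presence of trifluoromethyl, or both. Going by these compounds, compound 2 gives 8300 nM, and whether an amine, a carboxylic acid or a chlorine atom on this phenyl ring would give a much lower number remains open.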